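Methoxyphenyl Trimming on a Pyrazolopyrimidine Chalcone Series

This account rests on a few compounds, and the source may have more. Where it says the series, first, only, none or still open, it means among the compounds named here.

Compound 1 `COc1ccc(-c2cc(/C=C/C(=O)c3ccc(C)cc3)nc3cc(-c4ccccc4)nn23)cc1OC`: 62600 nM
Compound 2 `COc1cc(-c2cc(/C=C/C(=O)c3ccc(C)cc3)nc3cc(-c4ccccc4)nn23)cc(OC)c1OC`: 50400 nM
Compound 3 `COc1ccc(C(=O)/C=C/c2cc(-c3ccc(OC)c(OC)c3)n3nc(-c4ccccc4)cc3n2)cc1`: 40000 nM

Of the compounds shown here, three have been tested in an ADME assay on HEK293 cells (Homo sapiens) for antiproliferative activity, read by MTT assay, with a stated time of 24 h; a higher number here means a weaker inhibitor, a lower number a stronger inhibitor. Compound 1 gives 62600 nM, compound 2 gives 50400 nM, and compound 3 gives 40000 nM. Going from compound 2 to compound 1, the change is hydrogen in place of methoxy on an aromatic carbon, and the step is a 1.2-fold higher number from compound 2 to compound 1 (0.09 log units; within the scatter). From compound 1 to compound 3 the step is a 1.6-fold lower number from compound 1 to compound 3 (0.19 log units; within the scatter). The difference between the cores of compound 2 and compound 3 is not broken down here.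

Compound 4 `COc1ccc(C(=O)/C=C/c2cc(-c3ccc(OC)cc3)n3nc(-c4ccccc4)cc3n2)cc1` has not yet been measured. Its change from compound 3 is hydrogen in place of methoxy on an aromatic carbon. This is the same kind of change as that from compound 2 to compound 1, though the place is not identical: in compound 2 the leaving methoxy is also meta to a methoxy group, whereas in compound 3 it is not. Because the earlier step was a 1.2-fold higher number from compound 2 to compound 1 (0.09 log units; within the scatter), the step from compound 3 to compound 4 in this assay is expected to be small, about a 1.2-fold higher number from compound 3 to compound 4 (0.08 log units; within the scatter). Compound 4 is therefore estimated at 48000 nM, with a likely range of 25000 nM to 90000 nM.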

Compound 4, half-maximal inhibitory concentration: 36100 nM
The estimate for compound 4 lay 1.3-fold (0.12 log units) above the measured number, and the stated range covers the measured number.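

The cut from 3,4-dimethoxyphenyl to 4-methoxyphenyl gives, in this assay, a 1.1-fold lower number from compound 3 to compound 4 (0.04 log units; within the scatter), so removing this methoxy group leaves compound 4 within the scatter of compound 3. Set beside the same kind of change on the other core, the step carries over without a measurable difference: the same change on two cores in this assay, a 1.2-fold higher number (0.09 log units; within the scatter) from compound 2 to compound 1 and a 1.1-fold lower number (0.04 log units; within the scatter) from compound 3 to compound 4, 1.4-fold (0.14 log units) apart, within the scatter of two such steps This shows only that, across these two pairs in this assay, hydrogen in place of methoxy produced no step beyond the scatter on either core; it does not show that the change has no effect in general, and with no real effect to follow, it cannot show that an effect of a given size would transfer from one core to the other.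

The compounds shown leave open whether anything other than methoxy or hydrogen on this phenyl ring, such as an amine, a carboxylic acid or a fluorine, would move the number beyond the scatter. They also leave open whether either step would hold on a core with a longer chain in place of the present linker.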